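A few compounds are considered here, and "the series" means these few. Any claim that something is new, unique, unknown or untested is made for them only; others in the source may bear on it.

Working notes on the series. Compound 3 `CCn1c(SC/C(=N/O)c2ccccc2)nnc1-c1ccc(OC)c(OC)c1` stands with the highest of the three numbers measured in a functional assay on the whole organism (strain albino) for inhibition, with Rattus norvegicus as the target, read by paw edema, with a stated time of 4 h, at a dose of 0.28 mmol/kg by the oral route (a lower number here means less inhibition, a higher number more inhibition at the dose given (going by the name of the read-out)), where compound 3 gives 82%. Its nearest neighbour is compound 1 `COc1ccc(-c2nnc(SC/C(=N/O)c3ccccc3)n2-c2ccccc2)cc1`, which in this assay gives 80%, and the furthest is compound 2 `C=CCn1c(SC/C(=N/O)c2ccccc2)nnc1-c1ccc(OC)cc1`, which in this assay gives 76%. Both gaps lie within the scatter, so no order can be read among the three. Within the data shown here, the one step measured so far, a number 4 percentage points lower from compound 1 to compound 2 (within the scatter), alters a group on the aromatic nitrogen and stays within the scatter. Compound 4 `CCn1c(SC/C(=N/O)c2ccccc2)nnc1-c1ccc(OC)cc1` differs from compound 3 by hydrogen in place of methoxy on an aromatic carbon. No measured step touches a methoxy group on this six-membered ring, so nothing bears directly on the change, and the series as a whole has shown only small movements. The step from compound 3 to compound 4 is therefore expected to be a number 4 percentage points lower from compound 3 to compound 4 (within the scatter), a change not beyond the scatter. Compound 4 is estimated at 78%, with a range from 68% to 88%.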

Compound 4, a percentage reported as inhibition, in the whole organism at one dose (the size of the read-out at that dose, not a potency): 78%
The estimate for compound 4 equals the measured number at the digits printed, and the stated range covers the measured number.
By their numbers in this assay, from the lowest: compounds 2, 4, 1 and 3 (each within the scatter of the next).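

In this assay, among these compounds, a number 4 percentage points lower from compound 3 to compound 4 (within the scatter) is the first measured step at a place on the six-membered aromatic ring, ortho to a methoxy group and meta to a large group; with hydrogen in place of methoxy there, the read-out at this dose shows no change beyond the scatter. The ethyl group on the aromatic nitrogen also holds up against the allyl and phenyl groups, with a number 2 percentage points higher from compound 2 to compound 4 (within the scatter) and a number 2 percentage points lower from compound 1 to compound 4 (within the scatter), so three groups at that nitrogen now cannot be told apart. Nothing at hand speaks to the cause of these small steps.

The compounds shown all keep at least one methoxy group on that ring, so it stays open whether hydrogen, an amine or a carboxylic acid at the remaining methoxy place would give a step beyond the scatter. The oxime is likewise common to all four, and a ketone in its place would test whether it matters.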